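Notes on the pyrazole amide series: compound 2 to compound 4

The source may hold more compounds than are shown below. What is called first, only, known or untested is meant among the compounds shown, and "the series" means these compounds.

Measured in a functional assay on A2780 cells (Homo sapiens) for antiproliferative activity, read by fluorescence, with a stated time of 72 h; on this read-out higher numbers stand for weaker inhibition and lower numbers for stronger inhibition:
- compound 1 `CC1(C)c2[nH]nc(NC(=O)c3ccc(F)cc3)c2CN1C(=O)C1CCN(C2CC2)CC1` gives 380 nM
- compound 2 `CCCNC(=O)Nc1n[nH]c2c1CN(C(=O)C1CCN(C)CC1)C2(C)C` gives 650 nM
- compound 3 `CN1CCN(C(=O)N2Cc3c(NC(=O)c4ccc(F)cc4)n[nH]c3C2(C)C)CC1` gives 180 nM

Compound 2 stands at the upper end of these three numbers: its value lies within the scatter of compound 1, and it is higher than the value of compound 3 by a margin beyond the scatter.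

Compound 4 `CN1CCC(C(=O)N2Cc3c(NC(=O)c4ccncc4)n[nH]c3C2(C)C)CC1` has not yet been measured in this assay. It differs from compound 2 in one place: pyridin-4-yl in place of propylamino on a carbonyl carbon

Going by the values given here, the only step measured so far, a 2.1-fold lower number from compound 1 to compound 3 (0.32 log units; beyond the scatter), concerns the group on the other carbonyl carbon and does not touch the place changed here. Compound 1 and compound 2 differ in two places, so their values show only that an aryl amide and a propyl urea sit within the scatter of each other. Among the compounds with values here, no measured step directly covers an exchange of propylamino for pyridin-4-yl. Given that the two aryl amides, compound 1 and compound 3, give the lower numbers in this assay, the step of a 2.2-fold lower number from compound 2 to compound 4 (0.34 log units; beyond the scatter) is expected to be modest and downward, though it could also fall within the scatter. The value for compound 4 is therefore estimated at 300 nM, with a range from 120 nM to 800 nM.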

Compound 4, half-maximal inhibitory concentration: 500 nM
For compound 4 the middle estimate is 1.7-fold (0.22 log units) below the measured one, within the range that was stated.
By their numbers in this assay, from the lowest: compound 3; then compounds 1, 4 and 2 (each within the scatter of the next).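

Going by these compounds alone, the first direct reading at this position in this assay is a 1.3-fold lower number from compound 2 to compound 4 (0.11 log units; within the scatter). On this carbonyl carbon, the exchange removes the open chain and its hydrogen-bond donor and brings in a six-membered aromatic ring with a hydrogen-bond acceptor, yet the two numbers stay within the scatter of each other, so here the urea with propylamino and the amide with pyridin-4-yl cannot be told apart. No measurement of any property of these groups is available to account for this result.

Open, as far as these compounds go, is how a saturated amine such as piperidin-4-yl, or a longer chain such as hexylamino, would read on this carbonyl carbon. Also open is how pyridin-4-yl compares with the fluorophenyl group of compound 1 and compound 3, as no pair shown differs at this place alone.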